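A few compounds are considered here, and "the series" means these few. Any claim that something is new, unique, unknown or untested is made for them only; others in the source may bear on it.

Compound 1 `CC1=C(C(=O)OCC(C)C)C(c2csc(-c3ccc(Cl)cc3)n2)C(C(=O)OCC(C)C)=C(C)N1` and compound 2 `COC(=O)C1=C(C)NC(C)=C(C(=O)OCC(C)C)C1c1csc(-c2ccc(Cl)cc2)n1` share a core and differ only in one ester group. In an assay on isolated protein for antagonist activity at Voltage-dependent L-type calcium channel subunit alpha-1C (Cavia porcellus), with a stated time of 15 min (a higher number here means a weaker inhibitor, a lower number a stronger inhibitor), compound 1 gives 24900 nM, and in this assay compound 2 gives 46900 nM. Within the data shown here, the step between them, a 1.9-fold higher number from compound 1 to compound 2 (0.27 log units; within the scatter), is the only measured step in this set, and it does not rise above the usual scatter. Compound 2 therefore stands with the higher of the two numbers, but its gap to compound 1 is one that repeated measurements could erase.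

Compound 3 `CCOC(=O)C1=C(C)NC(C)=C(C(=O)OCC(C)C)C1c1csc(-c2ccc(Cl)cc2)n1` is the next member. It differs from compound 2 by methyl in place of hydrogen on a saturated chain carbon bound to an oxygen next to a carbonyl group. Among the measured compounds shown here, only the step from compound 1 to compound 2 bears on this change, since it touched the same ester position, and it was small. For compound 3 in this assay the step of a 1.3-fold lower number from compound 2 to compound 3 (0.13 log units; within the scatter) is expected, that is, nothing beyond the scatter. Compound 3 is estimated at 35000 nM, with a plausible range from 15000 nM to 80000 nM.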

Compound 3, half-maximal inhibitory concentration: 15400 nM
Compound 3: middle estimate off by 2.3-fold (0.36 log units), on the high side; the range from low to high includes it.
By their numbers in this assay, from the lowest: compounds 3, 1 and 2 (each within the scatter of the next, the first and the last beyond it).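

Read in this assay, this ester position now shows a step that clears the scatter: the change from methoxycarbonyl to ethoxycarbonyl gives a 3.0-fold lower number from compound 2 to compound 3 (0.48 log units; beyond the scatter) and thus separates two members of the set, although only modestly. The earlier change at this position did not do so, which shows that a methyl on this saturated chain carbon bound to an oxygen next to a carbonyl group is enough to produce a readable difference. The other comparison, methyl in place of isopropyl on that same carbon, gives a 1.6-fold lower number from compound 1 to compound 3 (0.21 log units; within the scatter) and stays within the scatter, so the effect of the substituent here does not follow a simple order across these compounds, and only the methoxycarbonyl compound stands apart, and only from compound 3.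

Still open is how this position responds to a straight propyl or butyl chain, or to an ester carrying an amine or a carboxylic acid at its far end, since all the groups shown here are small alkyl groups. No measurement in hand accounts for why the methyl makes this difference.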